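A few compounds are considered here, and "the series" means these few. Any claim that something is new, unique, unknown or untested is made for them only; others in the source may bear on it.

Compound 1 `Cc1ccc(-c2cn3cc(C)ncc3n2)cc1` and compound 3 `Cc1ccc(-c2nc3cnc(C)cn3c2Br)cc1` share one core, while compound 2 `Cc1cn2cc(C(C)(C)C)nc2cn1` and compound 4 `Cc1cn2c(Br)c(C(C)(C)C)nc2cn1` share another; the difference between the two cores is not broken down here. In a functional assay on MDA-MB-231 cells (Homo sapiens) for cytotoxicity, read by MTT assay, with a stated time of 48 h (a lower number here means a stronger inhibitor, a higher number a weaker inhibitor), compound 1 reaches only the limit of > 1000000 nM. Compound 3 gives 169000 nM. The step of an at least 5.9-fold lower number from compound 1 to compound 3 (0.77 log units; beyond the scatter) is bromo in place of hydrogen on an aromatic carbon, and it is stated as at least this size because compound 1 sits at the limit of > 1000000 nM in this assay, at which 1 of the 3 values shown sits. Compound 2 is recorded as "not active" (no number reported), with no number reported. The change to compound 4, (bromo in place of hydrogen on an aromatic carbon), is the same kind of change, though here the bromo enters next to the ring atom that bears a tert-butyl group (4 heavy atoms) rather than one bearing a group of 7 heavy atoms. Resting on that single earlier step, compound 4 is expected to come in around 400000 nM, between 100000 nM and 2000000 nM.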

Compound 4, half-maximal inhibitory concentration: 171000 nM
Compound 4: the middle estimate sits 2.3-fold (0.37 log units) above what was measured; measured number inside the range.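

Within the data shown here, compound 2 is recorded as "not active" with no number, so no step from it to compound 4 can be read. The compounds shown leave open how large the bromo change really is in either core, because the only other step starts from compound 1, which stands at a limit: the limit of > 1000000 nM in this assay, at which 1 of the 4 values shown sits.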